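Swapping the aryl amide group across two cores

This account rests on a few compounds, and the source may have more. Where it says the series, first, only, none or still open, it means among the compounds named here.

The measured compounds, all in a functional assay on K562/Adr cells (Homo sapiens) for inhibition, read by MTT assay, with a stated time of 48 h, tested at 30 uM; a higher number here means more inhibition at the concentration tested (going by the name of the read-out), a lower number less inhibition:
compound 1, `O=C(Nc1n[nH]c2cc(-c3cn([C@@H]4CN[C@H](C(=O)Nc5ccc(Cl)cc5Cl)C4)nn3)ccc12)C1CC1`, gives 43.3%
compound 2, `O=C(Nc1n[nH]c2cc(-c3cn([C@@H]4CN[C@H](C(=O)Nc5ccc(Br)cc5)C4)nn3)ccc12)C1CC1`, gives 39.6%
compound 3, `CC(C)(C)OC(=O)N1C[C@@H](n2cc(-c3ccc4nc(N)sc4n3)nn2)C[C@H]1C(=O)Nc1ccc(Cl)cc1Cl`, gives 28.3%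

Compound 1 and compound 2 share one core and differ only in the group on the amide nitrogen: 4-bromophenyl in place of 2,4-dichlorophenyl on an amide-type nitrogen. This change gave a number 3.7 percentage points lower from compound 1 to compound 2 (within the scatter), so the two values cannot be told apart in this assay. Compound 3 is built on a different core; how the two cores differ is not broken down here. Its value is the lowest of the three, lying beyond the scatter from both compound 1 and compound 2.

Compound 4, `CC(C)(C)OC(=O)N1C[C@@H](n2cc(-c3ccc4nc(N)sc4n3)nn2)C[C@H]1C(=O)Nc1ccc(Br)cc1`, has not yet been measured. It relates to compound 3 as compound 2 relates to compound 1: 4-bromophenyl in place of 2,4-dichlorophenyl on an amide-type nitrogen. The place is the same in both pairs, an amide-type nitrogen whose other neighbour is a carbonyl carbon, so this is the same change made once more on the other core. For the measured compounds named here, only one earlier example of it exists, which is a thin base. Because a number 3.7 percentage points lower from compound 1 to compound 2 (within the scatter) lay within the scatter, the step is expected to be small here as well, about a number 2.3 percentage points lower from compound 3 to compound 4 (within the scatter). Compound 4 is therefore expected to give about 26% in this assay, with a likely range from 14% to 38%. Whether the new core answers this swap differently cannot be known from these compounds.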

Compound 4, a percentage reported as inhibition, at one concentration (the size of the read-out at that concentration, not a potency): 31.7%
Compound 4: middle estimate off by 5.7 percentage points, on the low side; measured number inside the range.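

In this assay, putting 4-bromophenyl in place of 2,4-dichlorophenyl on the amide-type nitrogen gave a number 3.4 percentage points higher from compound 3 to compound 4 (within the scatter), so this pair cannot be told apart. Set beside the earlier case, the swap behaves alike on the two cores as far as this read-out can tell: the same change on two cores in this assay, a number 3.7 percentage points lower (within the scatter) from compound 1 to compound 2 and a number 3.4 percentage points higher (within the scatter) from compound 3 to compound 4, 7.1 percentage points apart, within the scatter of two such steps. This shows that, in these four compounds, the swap leaves no readable mark on either core, but it does not show that the change is truly without effect or that the opposite directions of the two small steps mean anything, and with one pair per core and a single tested concentration, it offers no general rule for other cores in the series.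

The compounds shown leave open how this place on the amide nitrogen responds to something very different from a halogen-bearing phenyl, such as a longer alkyl chain or a chain ending in an amine or a carboxylic acid. On these data alone, both swaps also trade one halogen pattern for another, so what a plain phenyl with no halogen would give on either core remains unknown.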